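Swapping a propyl urea for a phenethyl amide: cytotoxicity outlook

The source may hold more compounds than are shown below. What is called first, only, known or untested is meant among the compounds shown, and "the series" means these compounds.

Compound 2 `CCCNC(=O)Nc1cc2nc(C3CCCCC3)[nH]c2cc1N1CCCC1` was tested in an ADME assay on Vero cells (Chlorocebus sabaeus) for cytotoxicity, read by resazurin assay, with a stated time of 3 days (on this read-out higher numbers stand for weaker inhibition and lower numbers for stronger inhibition), and gave only a limit, > 100 ug/mL, so no number marks where it stands. Two close relatives were tested the same way. Compound 1 `CN(C)c1cc2[nH]c(C3CCCCC3)nc2cc1NC(=O)c1ccc(Br)cc1` gave > 100 ug/mL, likewise a limit. Compound 3 `CCCCOC(=O)Nc1cc2nc(C3CCCCC3)[nH]c2cc1N(C)C` gave > 100 ug/mL, again a limit. Among the measured compounds shown here, the one comparable change, butoxy in place of 4-bromophenyl on a carbonyl carbon, is a step that the two limits leave unreadable from compound 1 to compound 3, and as the limit of > 100 ug/mL in this assay, at which 3 of the 3 values shown sit, shows, every value so far sits at the same limit. Compound 4 `O=C(CCc1ccccc1)Nc1cc2nc(C3CCCCC3)[nH]c2cc1N1CCCC1` is made from compound 2 by phenethyl in place of propylamino on a carbonyl carbon. For the measured compounds named here, no measured step speaks to this swap in size, and no measured step of any kind has been read as a number. The expected step that the limit leaves unreadable from compound 2 to compound 4 is therefore most likely not readable as a number either. Compound 4 is estimated at 150 ug/mL, within 60 ug/mL to 400 ug/mL.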

Compound 4, half-maximal inhibitory concentration: > 100 ug/mL
Compound 4: no number, only a limit (the forecaster's own chance of this, stated with the estimate: 80%); the middle value is on the limit's open side.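

Among the compounds shown here, compound 2 and compound 4 each give only a limit in this assay, not a number, so no step between them can be read: the limit of > 100 ug/mL in this assay, at which 4 of the 4 values shown sit.

The compounds shown leave open at what concentration any of them inhibits the cells, and whether phenethyl in place of propylamino changes that at all.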